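Swapping cyclopropyl for trifluoromethylphenyl on a soluble core

A few compounds are considered here, and "the series" means these few. Any claim that something is new, unique, unknown or untested is made for them only; others in the source may bear on it.

Among the measured compounds shown here, compound 1 `CN1CCC(C(=O)N2Cc3c(NC(=O)C4CC4)n[nH]c3C2(C)C)CC1` is one of three compounds measured in a physicochemical assay for solubility, at pH 7; a higher number here means a more soluble compound, a lower number a less soluble compound. In this assay compound 1 gives > 225000 nM, which is a limit of the assay rather than a number. Compound 3 `CN(C)CC(=O)Nc1n[nH]c2c1CN(C(=O)C(C)(C)C)C2(C)C` likewise gives in this assay > 225000 nM, also a limit. Compound 2 `CC(C)(C)C(=O)N1Cc2c(NC(=O)c3cccnc3)n[nH]c2C1(C)C` gives in this assay 207000 nM. For the measured compounds named here, the only measured step, an at least 1.0-fold higher number from compound 2 to compound 3 (0.03 log units; that floor lies within the scatter), concerns another group of the shared core and stays within the scatter, so it offers no guide to the change in compound 4 `CN1CCC(C(=O)N2Cc3c(NC(=O)c4ccc(C(F)(F)F)cc4)n[nH]c3C2(C)C)CC1`, which differs from compound 1 by 4-(trifluoromethyl)phenyl in place of cyclopropyl on a carbonyl carbon. With two of three values at the limit of > 225000 nM in this assay, at which 2 of the 3 values shown sit, the data set no size for such a step. Compound 4 is nevertheless expected to give 20000 nM, between 3000 nM and 120000 nM. The expected step is an at least 11-fold lower number from compound 1 to compound 4 (1.05 log units; beyond the scatter).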

Compound 4, solubility: 191000 nM
Compound 4: middle estimate off by 9.6-fold (0.98 log units), on the low side; the whole stated range lies below it.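

At this place, on a carbonyl carbon, 4-(trifluoromethyl)phenyl in place of cyclopropyl gives an at least 1.1-fold lower number from compound 1 to compound 4 (0.07 log units; that floor lies within the scatter). The earlier compounds shown here set no size for this change, and compound 4 now shows that a six-membered aromatic ring of carbon only can stand here with no step beyond the scatter to be read. Only a floor can be given for the step because the value of compound 1 is a limit: the limit of > 225000 nM in this assay, at which 2 of the 4 values shown sit.

As far as these compounds go, how large the true step is stays open. So does how a carboxylic acid or a morpholine in place of 4-(trifluoromethyl)phenyl would read in this assay.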